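The source may hold more compounds than are shown below. What is called first, only, known or untested is meant among the compounds shown, and "the series" means these compounds.

In a functional assay on RAW264.7 cells (Mus musculus) for inhibition, read by ELISA, with a stated time of 24 h (a lower number here means that less compound is needed, a higher number that more compound is needed for the effect), compound 1 (`CC/C=C\C[C@H]1C(=O)C=C[C@H]1CC(=O)OCCCCC`) gives 25000 nM and compound 2 (`CC/C=C\C[C@H]1C(=O)C=C[C@H]1CC(=O)OCCO`) gives 24000 nM while compound 3 (`CC/C=C\C[C@H]1C(=O)C=C[C@H]1CC(=O)OCCOC`) gives 27000 nM and stands level with both within the scatter. Compound 4 (`CC/C=C\C[C@H]1C(=O)C=C[C@H]1CC(=O)OC(C)C`) has isopropyl in place of 2-methoxyethyl on an oxygen next to a carbonyl group. The measured steps bearing on this change the group on that same oxygen: a 1.1-fold higher number from compound 1 to compound 3 (0.03 log units; within the scatter) and a 1.0-fold lower number from compound 1 to compound 2 (0.02 log units; within the scatter) as well as a 1.1-fold higher number from compound 2 to compound 3 (0.05 log units; within the scatter) give no step beyond the scatter. Isopropyl itself has no measured precedent among these compounds. In this assay the expected step is a 1.1-fold lower number from compound 3 to compound 4 (0.03 log units; within the scatter) and no larger shift is expected. Compound 4 is estimated at 25000 nM with 13000 nM to 45000 nM as the expected range.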

Compound 4, half-maximal effective concentration: 20000 nM
Estimate against measurement, compound 4: 1.3-fold (0.10 log units) above; low and high end bracket the measured number.
By their numbers in this assay, from the lowest: compounds 4, 2, 1 and 3 (each within the scatter of the next).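

In this assay isopropyl on the oxygen next to a carbonyl group stays level with all three earlier groups: a 1.4-fold lower number from compound 3 to compound 4 (0.13 log units; within the scatter) and a 1.2-fold lower number from compound 2 to compound 4 (0.08 log units; within the scatter) as well as a 1.3-fold lower number from compound 1 to compound 4 (0.10 log units; within the scatter). The series now covers pentyl, 2-hydroxyethyl, 2-methoxyethyl and isopropyl on this oxygen, with no step beyond the scatter. No measurement available here bears on the reason for this flat result.

Open, from the compounds shown here alone, is whether an amine, a carboxylic acid or a phenyl ring on this oxygen would give a step beyond the scatter. Also open, going by these compounds, is what an amide in place of the ester would do.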